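The compounds below may be only part of what the source reports. "The series", "measured", "known", "first", "only" and "open" are said of these compounds alone.

For the measured compounds named here, in a functional assay on A549 cells (Homo sapiens) for inhibition, with a stated time of 48 h (on this read-out lower numbers stand for stronger inhibition and higher numbers for weaker inhibition), compound 2 (`C[S+]([O-])/C=C/c1cc(=O)c2ccccc2o1`) gives 10000 nM, the only actual number available. Compound 1 (`COc1cc2oc(/C=C/[S+](C)[O-])cc(=O)c2cc1OC`) reads > 10000 nM, which is a limit of the assay and not a number. Compound 3 (`COc1ccc2oc(/C=C/[S+](C)[O-])cc(=O)c2c1`) departs from compound 2 by a single change: methoxy in place of hydrogen on an aromatic carbon, with methoxy in place of hydrogen on an aromatic carbon. Going by the values given here, no measured step isolates this change, so no shift beyond the scatter is expected in this assay. The expected step is a 1.2-fold higher number from compound 2 to compound 3 (0.08 log units; within the scatter). For compound 3, the estimated value is 12000 nM, within an expected range of 5000 nM to 30000 nM.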

Compound 3, half-maximal inhibitory concentration: 9000 nM
Compound 3: the middle estimate sits 1.3-fold (0.12 log units) above what was measured; low and high end bracket the measured number.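

In this assay, methoxy in place of hydrogen on an aromatic carbon gives a 1.1-fold lower number from compound 2 to compound 3 (0.05 log units; within the scatter), so at this position the change stays within the scatter. Compound 1 reads > 10000 nM, which is a limit of the assay and not a number. Hydrogen in place of methoxy on an aromatic carbon gives an at least 1.1-fold lower number from compound 1 to compound 3 (0.04 log units; that floor lies within the scatter), which is only a floor, so the true size of this step stays unknown: the limit of > 10000 nM in this assay, at which 1 of the 3 values shown sits.

The compounds shown leave open whether an amine or a carboxylic acid at this position would give a step beyond the scatter. They also leave open what a longer chain, such as butoxy, would do there.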